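A nitro group added to compound 2

This account rests on a few compounds, and the source may have more. Where it says the series, first, only, none or still open, it means among the compounds named here.

Compound 1 `Cc1[nH]c2ccccc2c(=O)c1/C=C/C(=O)OC(C)(C)C` in an ADME assay for permeability, using PAMPA, at pH 4 (on this read-out lower numbers stand for lower permeability and higher numbers for higher permeability), gives 105 10^-6 cm/s
Compound 2 `Cc1[nH]c2ccccc2c(=O)c1/C=C/c1ccccc1` in this assay gives 222 10^-6 cm/s

Of these two numbers, compound 2 holds the higher one, and the gap to compound 1 lies beyond the usual scatter. Compound 3 `Cc1[nH]c2ccccc2c(=O)c1/C=C/c1cccc([N+](=O)[O-])c1` differs from compound 2 by a single change, nitro in place of hydrogen on an aromatic carbon, meta to a large group. Going by the values given here, only one measured step is available (a 2.1-fold higher number from compound 1 to compound 2 (0.33 log units; beyond the scatter)). It is modest and concerns a different group in a different place, so it bears on this change only loosely. Among the compounds with values here, no measured compound carries a nitro, and the direction remains uncertain. A step of similarly modest size is expected in this assay, leaning towards a lower number (a 1.7-fold lower number from compound 2 to compound 3 (0.23 log units; within the scatter)). Compound 3 is estimated at 130 10^-6 cm/s (range 45 10^-6 cm/s to 300 10^-6 cm/s).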

Compound 3, apparent permeability: 509 10^-6 cm/s
The estimate for compound 3 lay 3.9-fold (0.59 log units) below the measured number; the whole stated range lies below it.
By their numbers in this assay, from the lowest: compound 1; then compound 2; then compound 3.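

In this assay, going by these compounds alone, nitro in place of hydrogen on an aromatic carbon, meta to a large group, gives a 2.3-fold higher number from compound 2 to compound 3 (0.36 log units; beyond the scatter), the first measured change on this six-membered aromatic ring of carbon only. The step shows that this place on the ring can take a group with hydrogen-bond acceptors, no hydrogen-bond donors and no net charge without the number falling; here it rises beyond the usual scatter, and compound 3 holds the highest number of the three. Nothing measured here accounts for this rise, so its reason remains unknown.

Whether the rise belongs to nitro itself or to this place on the ring stays open, as the compounds shown carry nitro at this one place only. Equally open, from the compounds shown here alone, is whether an amine, a carboxylic acid or a methoxy group at the same place would move the number the same way.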